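A few compounds are considered here, and "the series" means these few. Any claim that something is new, unique, unknown or untested is made for them only; others in the source may bear on it.

Notes on the series. Compound 1 `Cc1ccc(-c2cc(N3CCC(CNS(N)(=O)=O)CC3)ncn2)cc1` in a functional assay on HT-29 cells (Homo sapiens) for antiproliferative activity, read by sulforhodamine B assay, with a stated time of 48 h (on this read-out lower numbers stand for stronger inhibition of growth and higher numbers for weaker inhibition of growth), gives 33900 nM. Compound 2 `NS(=O)(=O)NCC1CCN(c2cc(-c3ccc(Cl)cc3)ncn2)CC1` in this assay gives 37700 nM. Within the data shown here, the one step between them, a 1.1-fold higher number from compound 1 to compound 2 (0.05 log units; within the scatter), is a swap of chloro for methyl on an aromatic carbon and leaves the read-out essentially unchanged. Among the measured compounds shown here, compound 2 thus carries the higher of the two numbers measured so far, but its gap to compound 1 is within the scatter, so neither can be called the weaker of the pair.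

Compound 3 `NS(=O)(=O)NCC1CCN(c2cc(-c3ccccc3Cl)ncn2)CC1` is the next member and has not been measured. It differs from compound 2 by 2-chlorophenyl in place of 4-chlorophenyl on an aromatic carbon, that is, the same atoms joined differently: the chlorine is moved around the ring rather than exchanged for another group. For the measured compounds named here, no measured step moves a substituent around that ring; the only step available, a 1.1-fold higher number from compound 1 to compound 2 (0.05 log units; within the scatter), shows that changing the group at the same position barely moves this assay. On that basis the expected step of a 1.0-fold lower number from compound 2 to compound 3 (0.02 log units; within the scatter) is none beyond the scatter, and compound 3 is estimated at 36000 nM, with a range from 15000 nM to 90000 nM.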

Compound 3, concentration for 50% growth inhibition: > 100000 nM
Compound 3: a limit, no number; the forecaster's own chance of this, stated with the estimate: 15%; middle value at least 2.7-fold (0.44 log units) from the limit.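

In this assay, where the chlorine sits on the phenyl ring matters in a way that the exchange of chloro for methyl did not suggest: that exchange gave a 1.1-fold higher number from compound 1 to compound 2 (0.05 log units; within the scatter), whereas 2-chlorophenyl in place of 4-chlorophenyl gives an at least 2.6-fold higher number from compound 2 to compound 3 (0.42 log units; beyond the scatter), and 2-chlorophenyl in place of 4-methylphenyl gives an at least 2.9-fold higher number from compound 1 to compound 3 (0.46 log units; beyond the scatter). The value of compound 3 is a limit of the assay and not a number, so both new steps give only a lower bound on their size: the limit of > 100000 nM in this assay, at which 1 of the 3 values shown sits. The leaving and entering groups have the same heavy atoms and the same counts of donors and acceptors, so the earlier near-silence of this position held for the two 4-substituted phenyl groups only and does not extend to the isomer.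

The compounds shown do not tell whether the step belongs to chlorine itself or to any group at the 2-position of the phenyl ring, which a 2-methylphenyl or a 2-aminophenyl group would separate. They also leave open how an unsubstituted phenyl group would stand against the two 4-substituted compounds.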